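Moving the carboxylic acid from an amine to an ether linker

The compounds below may be only part of what the source reports. "The series", "measured", "known", "first", "only" and "open" are said of these compounds alone.

Measured so far in a functional assay on HEK293 cells for agonist activity at Bile acid receptor (Homo sapiens), read by a luciferase reporter; a lower number here means that less compound is needed, a higher number that more compound is needed for the effect:
compound 1 `Cc1cc(C(F)(F)F)cc(OCc2c(-c3c(Cl)cccc3Cl)noc2C(C)C)n1` gives "not active" (no number reported)
compound 2 `CC(C)c1onc(-c2c(Cl)cccc2Cl)c1COc1ccc(N(C)Cc2cccc(C(=O)O)c2)c(C(F)(F)F)n1` gives 6 nM
compound 3 `CN(Cc1cccc(C(=O)O)c1)c1ccc(OCc2c(-c3c(Cl)cccc3Cl)noc2C2CC2)nc1C(F)(F)F` gives 2 nM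

Compound 1 carries no acid-bearing group and returns no number in this assay. Among the compounds with values here, compound 3 stands at the lowest of the two numbers reported; the only step on record, a 3.0-fold lower number from compound 2 to compound 3 (0.48 log units; beyond the scatter), concerns the small ring on the shared core and not the acid-bearing arm.

Compound 4 `O=C(O)c1ccc(OCc2ccc(OCc3c(-c4c(Cl)cccc4Cl)noc3C3CC3)nc2C(F)(F)F)cc1` differs from compound 3 in that arm: (4-carboxyphenoxy)methyl in place of (3-carboxybenzyl)(methyl)amino on an aromatic carbon. The acid and one ring of the arm remain, but the nitrogen with its methyl is exchanged for an oxygen, and the acid moves to a different position on that ring.

Within the data shown here, no measured step bears directly on this change, so the expectation rests only on the fact that compounds 2 and 3, both carrying an acid-bearing arm, give numbers while compound 1, without one, does not. The step of a 4.0-fold higher number from compound 3 to compound 4 (0.60 log units; beyond the scatter) is therefore expected to be modest, most likely a somewhat higher number. Compound 4 is estimated at 8 nM, within a range of 2 nM to 40 nM.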

Compound 4, half-maximal effective concentration: 38 nM
Estimate against measurement, compound 4: 4.8-fold (0.68 log units) below; measured number inside the range.
By their numbers in this assay, from the lowest: compound 3; then compound 2; then compound 4.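

Both arms keep a carboxylic acid and a carbon-only aromatic ring, with the same counts of hydrogen-bond donors and acceptors, yet this assay shows a 19-fold higher number from compound 3 to compound 4 (1.28 log units; beyond the scatter) at this position. An acid-bearing arm is therefore not enough on its own to hold the number low: the details of the arm matter here, although compound 4 still gives a number. No measurement on hand explains this difference.

This single change alters both the link to the ring and the place of the acid, so the compounds shown cannot separate the two effects. Open questions are whether a (3-carboxyphenoxy)methyl arm or a (4-carboxybenzyl)(methyl)amino arm would give a number nearer that of compound 3, and whether an amide could stand in for the carboxylic acid.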